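A few compounds are considered here, and "the series" means these few. Any claim that something is new, unique, unknown or untested is made for them only; others in the source may bear on it.

Compounds measured in a functional assay on A549 cells (Homo sapiens) for cytotoxicity, read by MTT assay, with a stated time of 72 h (a lower number here means a stronger inhibitor, a higher number a weaker inhibitor), so far:

Compound 1 `O=C(Nc1ccc(Oc2ccnc3[nH]ccc23)cc1)c1ccc(-c2ccc(F)cc2F)cn1`. In this assay compound 1 gives only a limit, > 10000 nM.
Compound 2 `Cc1ccc(-c2ccnc(C(=O)Nc3ccc(Oc4ccnc5[nH]ccc45)cc3)c2)cc1`. In this assay compound 2 likewise gives only a limit, > 10000 nM.
Compound 3 `O=C(Nc1ccc(Oc2ccnc3[nH]ccc23)cc1)c1cc(-c2ccc(C(F)(F)F)cc2)ccn1`. In this assay compound 3 gives 3950 nM.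

Among the measured compounds shown here, compound 3 therefore holds the only actual number; the other two results are limits (the limit of > 10000 nM in this assay, at which 2 of the 3 values shown sit). For the measured compounds named here, the one measured step, from compound 2 to compound 3, was an at least 2.5-fold lower number from compound 2 to compound 3 (0.40 log units; beyond the scatter), the change being trifluoromethyl in place of methyl on an aromatic carbon.

Compound 4 `Cc1cccc(-c2ccnc(C(=O)Nc3ccc(Oc4ccnc5[nH]ccc45)cc3)c2)c1` differs from compound 3 by 3-methylphenyl in place of 4-(trifluoromethyl)phenyl on an aromatic carbon. This undoes the trifluoromethyl-for-methyl change and moves the methyl to the 3-position, so the step from compound 2 to compound 3 bears on it in reverse: a rise of at least modest size is expected, quite possibly back to a limit. Compound 4 is estimated at 10000 nM, within 4000 nM to 30000 nM. The expected step is a 2.5-fold higher number from compound 3 to compound 4 (0.40 log units; beyond the scatter).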

Compound 4, half-maximal inhibitory concentration: 7010 nM
Beside the measured number, compound 4's estimate is 1.4-fold (0.15 log units) above it; low and high end bracket the measured number.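

In this assay, 3-methylphenyl in place of 4-(trifluoromethyl)phenyl at this carbon, opposite the ring nitrogen, gives a 1.8-fold higher number from compound 3 to compound 4 (0.25 log units; within the scatter), so trifluoromethyl is not required for a measured number here. Moving the methyl from the 4-position to the 3-position gives an at least 1.4-fold lower number from compound 2 to compound 4 (0.15 log units; that floor lies within the scatter), so the size of that change remains unresolved. Compound 2 gives only a limit, > 10000 nM.

Part of the series still gives no actual number: the limit of > 10000 nM in this assay, at which 2 of the 4 values shown sit. Whether an amine or a carboxylic acid on this phenyl ring would shift the number beyond the scatter remains open.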